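The source may report more compounds than this note shows. Statements on the series, on what has been measured and on what is new or still open speak of the compounds shown alone.

Working notes on the rhodanine-acetic acid series.

Compound 1 `Cc1ccc(Cn2c(/C=C3\SC(=S)N(CC(=O)O)C3=O)nc3ccc(F)cc32)cc1` and compound 2 `COc1ccc2nc(/C=C3\SC(=S)N(CC(=O)O)C3=O)n(Cc3ccc(C)cc3)c2c1` share a core and differ only by methoxy in place of fluoro on an aromatic carbon. In a functional assay on MDA-MB-231 cells (Homo sapiens) for cytotoxicity, read by MTT assay, with a stated time of 48 h (on this read-out lower numbers stand for stronger inhibition and higher numbers for weaker inhibition), compound 1 gives 3860 nM, and compound 2 gives 3770 nM; the step of a 1.0-fold lower number from compound 1 to compound 2 (0.01 log units; within the scatter) is within the scatter, so the two cannot be ordered. Compound 3 `O=C(O)CN1C(=O)/C(=C/c2nc3cc(F)ccc3n2Cc2ccccc2F)SC1=S` carries a different core; the difference between the two cores is not broken down here. In this assay compound 3 gives 22400 nM, the highest of the three numbers, with the gaps to compound 1 and compound 2 both beyond the scatter.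

Compound 4 `COc1ccc2c(c1)nc(/C=C1\SC(=S)N(CC(=O)O)C1=O)n2Cc1ccccc1F` is not yet measured. It differs from compound 3 by methoxy in place of fluoro on an aromatic carbon, at the same place as the change from compound 1 to compound 2, so it is the same change, made twice in all among these compounds. Because the earlier instance gave a 1.0-fold lower number from compound 1 to compound 2 (0.01 log units; within the scatter), the step of a 1.0-fold lower number from compound 3 to compound 4 (0.01 log units; within the scatter) is expected to be of the same small size. Compound 4 is therefore estimated at 22000 nM, with a likely range from 11000 nM to 45000 nM.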

Compound 4, half-maximal inhibitory concentration: 16900 nM
The estimate for compound 4 lay 1.3-fold (0.11 log units) above the measured number; measured number inside the range.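

In this assay the new step is a 1.3-fold lower number from compound 3 to compound 4 (0.12 log units; within the scatter), so compound 3 and compound 4 cannot be ordered. Methoxy in place of fluoro on this aromatic carbon thus leaves the number within the scatter on both cores, and the step carries from one core to the other with no difference that can be read: the same change on two cores in this assay, a 1.0-fold lower number (0.01 log units; within the scatter) from compound 1 to compound 2 and a 1.3-fold lower number (0.12 log units; within the scatter) from compound 3 to compound 4, 1.3-fold (0.11 log units) apart, within the scatter of two such steps This shows agreement for two pairs only, at one place and in one assay; it does not show that the same holds on any further core, and two steps that are both within the scatter say nothing about why the number stays put.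

Still open is whether an amine or a longer chain on the same aromatic carbon would also leave the number within the scatter, as the compounds shown carry only fluoro and methoxy there. Also open, going by these compounds, is whether methoxy in place of fluoro would stay this small at another place on the six-membered aromatic ring.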